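The compounds below may be only part of what the source reports. "The series", "measured", "known", "first", "only" and "open" are said of these compounds alone.

In a functional assay on HT-29 cells (Homo sapiens) for inhibition, read by sulforhodamine B assay, with a stated time of 48 h (on this read-out higher numbers stand for weaker inhibition of growth and lower numbers for stronger inhibition of growth), three compounds sharing one core have been measured so far. Compound 1 `COc1ccc(CNc2nc3cc(N)cc(N)c3nc2-c2ccccc2)cc1OC` gives 24500 nM, compound 2 `COc1cc(CNc2nc3cc(N)cc(N)c3nc2-c2ccccc2)cc(OC)c1OC` gives 19500 nM, and compound 3 `Nc1cc(N)c2nc(-c3ccccc3)c(NCc3ccc(F)cc3)nc2c1` gives 12600 nM. Compound 3 stands at the low end of these three numbers, but its gaps to compound 1 and compound 2 lie within the scatter, so the three cannot be told apart. Compound 4 `COc1ccc(CNc2nc3cc(N)cc(N)c3nc2-c2ccccc2)cc1` differs from compound 3 by methoxy in place of fluoro on an aromatic carbon. Within the data shown here, two measured steps bear on this change: a 1.9-fold lower number from compound 1 to compound 3 (0.29 log units; within the scatter) and a 1.3-fold lower number from compound 1 to compound 2 (0.10 log units; within the scatter), both within the scatter. In this assay the expected step of a 1.2-fold higher number from compound 3 to compound 4 (0.08 log units; within the scatter) is therefore none beyond the scatter. Compound 4 is estimated to give 15000 nM, within a range of 7000 nM to 35000 nM.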

Compound 4, concentration for total growth inhibition: 60300 nM
The estimate for compound 4 lay 4.0-fold (0.60 log units) below the measured number; the measured number lies above the stated range.
By their numbers in this assay, from the lowest: compounds 3, 2 and 1 (each within the scatter of the next); then compound 4.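

In this assay, this aromatic carbon, para to a large group, now gives a step beyond the scatter: methoxy in place of fluoro brings a 4.8-fold higher number from compound 3 to compound 4 (0.68 log units; beyond the scatter) in the number. Hydrogen in place of methoxy on an aromatic carbon also matters, with a 2.5-fold higher number from compound 1 to compound 4 (0.39 log units; beyond the scatter), so the lone 4-methoxyphenyl of compound 4 reads weaker than either neighbour, and a methoxy's effect here depends on what else the ring carries. No measurement shown explains either step. From the compounds shown here alone, whether a hydroxyl or an amine on this carbon would read like fluoro or like methoxy stays open.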